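Series notes: cyclopropyl to 1,1-difluoroethyl on the core

This account rests on a few compounds, and the source may have more. Where it says the series, first, only, none or still open, it means among the compounds named here.

Measured so far:
compound 1, `Cc1cc(Nc2ccc(S(F)(F)(F)(F)F)cc2)n2nc(C3CC3)nc2n1`: 3.5
compound 2, `Cc1cc(Nc2ccc(C(F)(F)F)cc2)n2nc(C3CC3)nc2n1`: 3.3

Among the measured compounds shown here, in a physicochemical assay for lipophilicity, at pH 7.4 (a lower number here means a more polar compound, a higher number a more lipophilic compound), compound 1 gives 3.5 and stands highest of the two numbers measured; the only other value lies a number 0.20 log units lower from compound 1 to compound 2 (within the scatter), so the two compounds cannot be ordered against each other. Compound 3, `Cc1cc(Nc2ccc(S(F)(F)(F)(F)F)cc2)n2nc(C(C)(F)F)nc2n1`, has not yet been measured in this assay. It differs from compound 1 by 1,1-difluoroethyl in place of cyclopropyl on an aromatic carbon. For the measured compounds named here, the one measured step, a number 0.20 log units lower from compound 1 to compound 2 (within the scatter), concerns a different change at a different place and does not bear on this one; no measured pair shows the exchange of cyclopropyl for 1,1-difluoroethyl, so the expectation rests on compound 1 alone. A small step, most likely within the scatter, is expected, a number 0.20 log units lower from compound 1 to compound 3 (within the scatter). Compound 3 is therefore estimated at 3.3, with a range from 2.9 to 3.7.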

Compound 3, distribution coefficient: 3.6
Compound 3: middle estimate off by 0.30 log units, on the low side, and the stated range covers the measured number.
By their numbers in this assay, from the lowest: compounds 2, 1 and 3 (each within the scatter of the next).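

Among the compounds shown here, the step of a number 0.10 log units higher from compound 1 to compound 3 (within the scatter) in this assay is the first reading at this place, on an aromatic carbon between two ring nitrogen atoms; the earlier step concerned the other end of the molecule. With 1,1-difluoroethyl in place of cyclopropyl, an open group carrying fluorine replaces a carbon-only ring, yet the two compounds cannot be told apart in this read-out. No evidence at hand bears on why the two groups read alike.

From the compounds shown here alone, whether the same holds with the trifluoromethyl group of compound 2 in place of the sulfur-bearing group stays open. So does how a more different group at this place, such as an amine or a carboxylic acid, would compare in this assay with cyclopropyl and 1,1-difluoroethyl.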